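A few compounds are considered here, and "the series" means these few. Any claim that something is new, unique, unknown or untested is made for them only; others in the source may bear on it.

Working notes on the series. Compound 1 `Cc1cnn(C(=O)NCc2ccc(OC(c3ccccc3)c3ccccc3)cc2)c1` has no result in an assay on membranes from brain for binding affinity to Monoacylglycerol lipase ABHD6 (Mus musculus), read by fluorescence, with stated times of 1 h and 30 min; a lower number here means a stronger inhibitor, a higher number a weaker inhibitor: in this assay compound 1 is reported as "not determined" (no result reported). Compound 2 `Cc1cnn(C(=O)N2CCN(C(c3ccc4ccccc4c3)c3ccc4ccccc4c3)CC2)c1` carries the shared core on a different amine; in this assay compound 2 reaches only the limit > 100000 nM. Compound 3 `O=C(N1CCN(C(c2ccc3ccccc3c2)c2ccc3ccccc3c2)CC1)n1cccn1` follows from compound 2 by hydrogen in place of methyl on an aromatic carbon; in this assay compound 3 likewise gives only the limit > 100000 nM. The step that the two limits leave unreadable from compound 2 to compound 3 is therefore not readable, both ends sitting at the limit of > 100000 nM in this assay, at which 2 of the 3 values shown sit. Compound 3 thus stands at the edge of what this assay reports, with no single number among the three entries: one further limit and one entry without a number.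

Compound 4 `N#Cc1cnn(C(=O)N2CCN(C(c3ccc4ccccc4c3)c3ccc4ccccc4c3)CC2)c1` follows from compound 3 by cyano in place of hydrogen on an aromatic carbon. Among the measured compounds shown here, no measured step bears on this change; the only step in the set is unreadable and concerns a different group. Nothing among the values points to a step of a particular size or direction in this assay. Compound 4 is expected to remain near the limit, with an estimated 100000 nM in this assay, within 10000 nM to 300000 nM. The step of a number no higher from compound 3 to compound 4 (the limit leaves the size open) is expected to be none beyond the scatter, and a limit rather than a number is expected to be the likelier outcome.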

Compound 4, half-maximal inhibitory concentration: 560 nM
Compound 4: the middle estimate sits 180-fold (2.25 log units) above what was measured; the measured number lies below the stated range.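

In this assay, the aromatic carbon two ring bonds from the ring nitrogen and two ring bonds from the ring atom that bears a large group proves able to move the read-out: cyano in place of hydrogen gives an at least 170-fold lower number from compound 3 to compound 4 (2.25 log units; beyond the scatter), and cyano in place of methyl gives an at least 170-fold lower number from compound 2 to compound 4 (2.25 log units; beyond the scatter). Of the three groups shown at this position, only cyano brings the read-out to a number, so this single change on the pyrazole separates compound 4 from compound 2 and compound 3. Both steps start from a value that is a limit and not a number: the limit of > 100000 nM in this assay, at which 2 of the 4 values shown sit.

As far as these compounds go, whether the change is specific to cyano stays open, as a chlorine, a carboxamide or a carboxylic acid on the same carbon would show. Also open, from the compounds shown here alone, is whether cyano gives a similar step with a different amine on the shared core.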